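Enantiomer swap in the somatostatin receptor binding series

The source may hold more compounds than are shown below. What is called first, only, known or untested is meant among the compounds shown, and "the series" means these compounds.

Compound 2 `COC(=O)c1cc(CC(C)CN2C[C@H]3CCCC[C@H]3[C@@H](C(=O)N3CCN(c4ccc([N+](=O)[O-])cc4)CC3)C2)cc(C(=O)OC)c1` stands at 2340 nM in an assay on isolated protein for binding affinity to somatostatin receptor type 1 (Homo sapiens) (on this read-out higher numbers stand for weaker binding and lower numbers for tighter binding), the highest of the two numbers in hand. Its nearest neighbour is compound 1 `COC(=O)c1cc(CC(C)CN2CC3CCCCC3C(C(=O)N3CCN(c4ccc([N+](=O)[O-])cc4)CC3)C2)cc(C(=O)OC)c1`, which in this assay gives 1000 nM. For the measured compounds named here, the step of a 2.3-fold higher number from compound 1 to compound 2 (0.37 log units; beyond the scatter) is the only measured step in the set, and it is a step in drawn stereochemistry rather than in atoms; the fact that one of compounds 1 and 2 is drawn with a defined configuration and the other without, at the place where they differ is the one observation that bears on it.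

Compound 3 `COC(=O)c1cc(CC(C)CN2C[C@@H]3CCCC[C@@H]3[C@H](C(=O)N3CCN(c4ccc([N+](=O)[O-])cc4)CC3)C2)cc(C(=O)OC)c1` is the next compound to be measured. The change from compound 2 is the two compounds have the same atoms and bonds; at least one stereo element is drawn with a configuration in one of them and without one in the other: 3 of 4 stereo elements differ; a stereocentre at a saturated ring carbon is drawn S in compound 2 and R in compound 3; a stereocentre at a saturated ring carbon is drawn R in compound 2 and S in compound 3; a stereocentre at a saturated ring carbon is drawn R in compound 2 and S in compound 3, so compound 3 is the mirror image of compound 2 at those three ring centres, with the same atoms and bonds throughout. The measured step from compound 1 to compound 2 bears on this: compound 1, drawn without configuration at these centres, sits at the lower number, while compound 2 with one drawn configuration sits higher. The step expected for compound 3 is therefore a move to a lower number, a 3.6-fold lower number from compound 2 to compound 3 (0.56 log units; beyond the scatter), estimated rather than known. Compound 3 is expected to give 650 nM in this assay, with a range of 200 nM to 2000 nM.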

Compound 3, dissociation constant: 398 nM
For compound 3 the middle estimate is 1.6-fold (0.21 log units) above the measured one, and the stated range covers the measured number.
By their numbers in this assay, from the lowest: compound 3; then compound 1; then compound 2.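

In this assay the three ring centres now show that configuration alone shifts the read-out: with atoms and bonds unchanged, the mirror-image arrangement gives a 5.9-fold lower number from compound 2 to compound 3 (0.77 log units; beyond the scatter). Against the form drawn without configuration at these centres, the step is a 2.5-fold lower number from compound 1 to compound 3 (0.40 log units; beyond the scatter), so compound 3 has the lowest number of the three, with its steps to both others beyond the scatter, and compound 1 falls between the two drawn forms. The gap between the drawn forms is wider than either step from the undefined form, and the only recorded difference behind it is one of drawn stereochemistry: the fact that one of compounds 2 and 3 is drawn with a defined configuration and the other without, at the place where they differ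

The drawings do not tell what stereoisomer composition compound 1 has, and the fourth stereo element stays undefined in compounds 2 and 3, so its contribution remains unresolved. Also open, on these data alone, is whether the ordering of the drawn forms would persist with a carboxylic acid in place of the methyl esters or an amine in place of the nitro group.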